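This account rests on a few compounds, and the source may have more. Where it says the series, first, only, none or still open, it means among the compounds named here.

Of the compounds shown here, three with a shared core have been measured in an assay on cells for activation of Cystic fibrosis transmembrane conductance regulator (Homo sapiens), read by fluorescence, with stated times of 10 min and 12 s; on this read-out higher numbers stand for an effect only at larger amounts of compound and lower numbers for an effect already at smaller amounts. Compound 1 `CCN(CC)c1nc(Nc2ccccc2)nc(OCC(F)(F)C(F)F)n1` gives 2000 nM. Compound 2 `CCN(CC)c1nc(Nc2cccc(C(=O)O)c2)nc(OCC(F)(F)C(F)F)n1`, carrying a carboxy group on the phenyl ring, gives 500 nM. Compound 3 `CCN(CC)c1nc(Nc2cccc(F)c2)nc(OCC(F)(F)C(F)F)n1` gives 1600 nM. Among these three numbers compound 3 has the second highest; it sits close to compound 1, with a difference that lies within the scatter, and furthest from compound 2, from which it differs beyond the scatter.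

Compound 4 `CCN(CC)c1nc(Nc2cccc([N+](=O)[O-])c2)nc(OCC(F)(F)C(F)F)n1` has not yet been measured. It differs from compound 3 in one place: nitro in place of fluoro on an aromatic carbon. For the measured compounds named here, no measured step puts a nitro group at this position, so the guide comes from the other changes made there. A fluoro at this place changed little, as a 1.3-fold lower number from compound 1 to compound 3 (0.10 log units; within the scatter) shows, whereas a carboxy lowered the number modestly, as a 4.0-fold lower number from compound 1 to compound 2 (0.60 log units; beyond the scatter) shows, and exchanging carboxy for fluoro raised it again, a 3.2-fold higher number from compound 2 to compound 3 (0.51 log units; beyond the scatter). Since the nitro group, like the carboxy, brings oxygen acceptors to this place, a small lowering is expected, estimated as a 1.6-fold lower number from compound 3 to compound 4 (0.20 log units; within the scatter), though a result within the scatter would not surprise. Compound 4 is therefore expected to give about 1000 nM, with a likely range from 400 nM to 2500 nM.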

Compound 4, half-maximal effective concentration: 1200 nM
Compound 4: the middle estimate sits 1.2-fold (0.08 log units) below what was measured, within the range that was stated.
By their numbers in this assay, from the lowest: compound 2; then compounds 4, 3 and 1 (each within the scatter of the next).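

In this assay, a nitro group at this place does not match the carboxy group: the exchange between them gives a 2.4-fold higher number from compound 2 to compound 4 (0.38 log units; beyond the scatter), while the other two steps, a 1.3-fold lower number from compound 3 to compound 4 (0.12 log units; within the scatter) and a 1.7-fold lower number from compound 1 to compound 4 (0.22 log units; within the scatter), cannot be told from repeat-measurement scatter. Hydrogen, fluoro and nitro therefore cannot be separated here, and only the carboxy of compound 2 stands apart from them, so hydrogen-bond acceptors on this carbon are not enough, in these compounds, to reproduce its step. Nothing available here explains why the carboxy group differs from the other three.

From the compounds shown here alone, it remains open whether an amide or a methyl ester at this place would fall with compound 2 or with the other three. Also open, going by these compounds, is how a carboxylic acid would fare on a different carbon of this ring.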